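Aryl exchange on the fused core: outlook for compound 3

This account rests on a few compounds, and the source may have more. Where it says the series, first, only, none or still open, it means among the compounds named here.

Going by the values given here, compound 2 `COc1ccc2cc(C(C)c3nnc4n3N=C(c3ccc(Cl)cc3Cl)CS4)ccc2c1` stands at the highest of the two numbers measured so far: in a functional assay on MCF7 cells (Homo sapiens) for inhibition, read by sulforhodamine B assay, with a stated time of 72 h (on this read-out higher numbers stand for weaker inhibition and lower numbers for stronger inhibition), compound 2 gives 14600 nM. Its nearest neighbour is compound 1 `COc1ccc2cc(C(C)c3nnc4n3N=C(c3ccc(OC(F)(F)F)cc3)CS4)ccc2c1`, which in this assay gives 8800 nM. Compound 3 `COc1ccc2cc(C(C)c3nnc4n3N=C(c3ccc(F)cc3)CS4)ccc2c1` carries 4-fluorophenyl in place of 2,4-dichlorophenyl on a carbon with a double bond to nitrogen. Among the compounds with values here, only one measured step concerns the same position, the exchange of the aryl group on the carbon with a double bond to nitrogen, and that step, a 1.7-fold higher number from compound 1 to compound 2 (0.22 log units; within the scatter), stayed within the scatter. An exchange of one aryl group for another at this position has thus not yet moved the number beyond the scatter, and nothing measured points in either direction. The step from compound 2 to compound 3 in this assay is therefore expected to be a 1.3-fold lower number from compound 2 to compound 3 (0.12 log units; within the scatter), that is, none beyond the scatter. Compound 3 is accordingly estimated at 11000 nM in this assay, within a range from 4000 nM to 32000 nM.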

Compound 3, half-maximal inhibitory concentration: 15800 nM
Compound 3: middle estimate off by 1.4-fold (0.16 log units), on the low side, and the stated range covers the measured number.
By their numbers in this assay, from the lowest: compounds 1, 2 and 3 (each within the scatter of the next).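

In this assay the aryl exchange on the carbon with a double bond to nitrogen now has two further steps, a 1.1-fold higher number from compound 2 to compound 3 (0.03 log units; within the scatter) and a 1.8-fold higher number from compound 1 to compound 3 (0.25 log units; within the scatter), and both stay within the scatter. All three aryl groups shown, 4-(trifluoromethoxy)phenyl, 2,4-dichlorophenyl and 4-fluorophenyl, therefore give numbers within the scatter of one another, so this place has yet to separate any two compounds, whether the change is the swap of 2,4-dichlorophenyl for 4-fluorophenyl or of trifluoromethoxy for fluoro on the aromatic carbon. No information is at hand that would account for this flat result.

From the compounds shown here alone, whether a phenyl carrying an amine or a carboxylic acid, or a saturated cyclohexyl ring, would move the number beyond the scatter at this place remains open. The three compounds also share everything else, so the contribution of the methoxy group on the shared core is open as well.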